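A few compounds are considered here, and "the series" means these few. Any claim that something is new, unique, unknown or untested is made for them only; others in the source may bear on it.

Compound 2, `O=C1c2ccc(OCc3cccc(-c4ccccc4)c3)cc2CN1C1CCCC1`, has no result in an assay on HEK293 cells for positive allosteric modulation of metabotropic glutamate receptor 2 (Rattus norvegicus), read by thallium flux; on this read-out higher numbers stand for larger maximal responses and lower numbers for smaller maximal responses: for compound 2 the entry reads "not determined" (no result reported), so where it stands on this read-out is open. Two compounds on a related core carry the kind of aryl group at issue here: compound 1, `O=C(O)c1cc(-c2cccc(COc3ccc4c(=O)n(CC5CC5)sc4c3)c2)ccc1Cl`, reaches 38.4% in this assay, and compound 3, `CN(C)C(=O)c1cc(-c2cccc(COc3ccc4c(=O)n(C5CCCC5)sc4c3)c2)ccc1Cl`, reaches 54.8%. Compound 4, `O=C(O)c1ccc(Cl)c(-c2cccc(COc3ccc4c(c3)CN(C3CCCC3)C4=O)c2)c1`, arises from compound 2 by 5-carboxy-2-chlorophenyl in place of phenyl on an aromatic carbon. Among the measured compounds shown here, no measured step covers this change on the core of compound 2, so the size of the step in this assay cannot be taken from a measured pair; a moderate maximal response is expected, with compound 1 at 38.4% as the nearest comparison. Compound 4 is estimated at 42%, with a range of 22% to 68%.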

Compound 4, largest response reached (reported as percent of maximum), in percent of the reference or control that the assay uses: 93.9%
Compound 4: the middle estimate sits 51.9 percentage points below what was measured, outside the stated range (above it).
By their numbers in this assay, from the lowest: compound 1; then compound 3; then compound 4.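

Among the compounds shown here, no step can be read from this result: compound 2 and compound 4 give no pair of values, and compound 1 and compound 3 differ from compound 4 in more than one place. As far as these compounds go, what 5-carboxy-2-chlorophenyl in place of phenyl does in this assay stays open. No evidence on the result is available.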